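A few compounds are considered here, and "the series" means these few. Any claim that something is new, unique, unknown or untested is made for them only; others in the source may bear on it.

Measured so far:
compound 1 `O=C(CSc1nc(Nc2ccccc2)c2ccccc2n1)Nc1ccc(Cl)cc1Cl` with 9110 nM
compound 2 `C=CC(=O)Nc1cccc(NC(=O)CSc2nc(Nc3cccc([N+](=O)[O-])c3)c3ccccc3n2)c1` with 46300 nM

In a functional assay on PC-3 cells (Homo sapiens) for inhibition, read by MTT assay, with a stated time of 72 h (on this read-out lower numbers stand for stronger inhibition and higher numbers for weaker inhibition), compound 2 stands at the higher, weaker, of the two numbers; compound 1 lies beyond the scatter from it. Compound 3 `C=CC(=O)Nc1cccc(NC(=O)CSc2nc(Nc3ccc(Cl)cc3Cl)c3ccccc3n2)c1` keeps the rest of compound 2 and carries one change: 2,4-dichlorophenyl in place of 3-nitrophenyl on a nitrogen on an aromatic ring. Going by the values given here, the group that enters is the one found in compound 1, whose value in this assay is 9110 nM. Among the compounds with values here, no measured step is recorded for this change, so any expectation rests on that likeness alone. A step toward stronger inhibition is expected, a 3.1-fold lower number from compound 2 to compound 3 (0.49 log units; beyond the scatter). Compound 3 is estimated at 15000 nM, within 5000 nM to 45000 nM.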

Compound 3, half-maximal inhibitory concentration: 25700 nM
Compound 3: the middle estimate sits 1.7-fold (0.23 log units) below what was measured; the range from low to high includes it.
By their numbers in this assay, from the lowest: compound 1; then compounds 3 and 2 (each within the scatter of the next).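

In this assay, 2,4-dichlorophenyl in place of 3-nitrophenyl on a nitrogen on an aromatic ring gives a step within the scatter (a 1.8-fold lower number from compound 2 to compound 3 (0.26 log units; within the scatter)). This first measured step at this position therefore does not separate the two groups, even though they differ in the atoms they carry on the ring. No measurement shown here gives a reason for this result. Still open, going by these compounds, is whether a methoxyphenyl or a pyridyl group on that nitrogen would separate from these two, since only these two groups can be compared directly here.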